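Removing one methyl from a tetramethoxy isoflavone analogue

This account rests on a few compounds, and the source may have more. Where it says the series, first, only, none or still open, it means among the compounds named here.

Measured compounds:
Compound 1, `C=CC(C)(C)c1cc(OC(C)=O)c(OC(C)=O)cc1-c1coc2cc(OC(C)=O)cc(OC(C)=O)c2c1=O`, gives 66200 nM.
Compound 2, `CC1(C)CCc2c(-c3coc4cc(O)cc(O)c4c3=O)ccc(O)c2O1`, gives 107000 nM.
Compound 3, `C=CC(C)(C)c1cc(OC)c(OC)cc1-c1coc2cc(OC)cc(OC)c2c1=O`, gives 134000 nM.

These three compounds were tested in an ADME assay on PC-3 cells (Homo sapiens) for cytotoxicity; on this read-out lower numbers stand for stronger inhibition and higher numbers for weaker inhibition. All three give high numbers, so none of them is a strong inhibitor of cell growth here. Compound 3 gives the highest of the three numbers. Its nearest neighbour is compound 2, whose number is only slightly lower and within the usual scatter of the measurement, so the two cannot be told apart. Compound 1 gives a lower number than compound 3, a gap that lies beyond the scatter.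

Compound 4, `C=CC(C)(C)c1cc(OC)c(OC)cc1-c1coc2cc(OC)cc(O)c2c1=O`, has not been measured yet. It differs from compound 3 in one place: hydrogen in place of methyl on an oxygen on an aromatic ring. Among the compounds with values here, no measured pair shows the effect of this exact change, so there is no direct step to lean on. Given that compound 2, which carries free hydroxy groups, gives 107000 nM, a number close to that of compound 3, the change is not expected to move the read-out much. The step of a 1.2-fold lower number from compound 3 to compound 4 (0.09 log units; within the scatter) is expected to stay within the scatter. Compound 4 is therefore estimated at 110000 nM, with a likely range from 50000 nM to 250000 nM.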

Compound 4, half-maximal inhibitory concentration: 146000 nM
Estimate against measurement, compound 4: 1.3-fold (0.12 log units) below; low and high end bracket the measured number.
By their numbers in this assay, from the lowest: compounds 1, 2, 3 and 4 (each within the scatter of the next, the first and the last beyond it).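

In this assay, going from methoxy to hydroxy on an oxygen on an aromatic ring gives a 1.1-fold higher number from compound 3 to compound 4 (0.04 log units; within the scatter), so compound 3 and compound 4 cannot be told apart. Within the data shown here, this is the first direct reading of the change, since the earlier compounds differ from one another in more than one place. At this position, then, the methyl on the oxygen can be replaced by hydrogen without a change that this read-out can resolve. Nothing measured here gives a reason for this result.

The compounds shown leave open whether the other methoxy groups on the shared core would tolerate the same swap. They also leave open whether a different group on this oxygen, such as a longer butoxy chain or a chain ending in a carboxylic acid or an amine, would move the number.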